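The source may hold more compounds than are shown below. What is called first, only, known or untested is meant among the compounds shown, and "the series" means these compounds.

Measured compounds:
compound 1, `N=C(N)N/N=C/c1c(-c2ccncc2)nc2sc(Cl)cn12`, in a functional assay on CNS cells (Homo sapiens) for antiproliferative activity (a lower number here means a stronger inhibitor of growth, a higher number a weaker inhibitor of growth), compound 1 gives 7760 nM
compound 2, `Cc1cn2c(/C=N/NC(=N)N)c(-c3cccnc3)nc2s1`, in this assay compound 2 gives 12000 nM

Compound 2 has the highest of the two numbers in this assay, but its nearest neighbour, compound 1, lies within the scatter of it, so the two cannot be ranked against each other. Compound 3, `N=C(N)N/N=C/c1c(-c2cccnc2)nc2sc(Cl)cn12`, has not been measured in this assay. It differs from compound 2 in one place: chloro in place of methyl on an aromatic carbon. Within the data shown here, no pair of measured compounds shows what this single change does, since compound 1 and compound 2 differ in two places at once. The two known values give no footing for more than a small step, and a drift toward a lower number is considered only because compound 1, which carries the chloro group, gives 7760 nM. Compound 3 is therefore expected to land near compound 2, with a step of a 1.3-fold lower number from compound 2 to compound 3 (0.12 log units; within the scatter) that is expected to stay within the scatter, at an estimated 9000 nM between 4000 nM and 20000 nM.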

Compound 3, concentration for 50% growth inhibition: 15100 nM
Estimate against measurement, compound 3: 1.7-fold (0.22 log units) below; the range from low to high includes it.
By their numbers in this assay, from the lowest: compounds 1, 2 and 3 (each within the scatter of the next).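

In this assay, chloro in place of methyl on the aromatic carbon next to the ring sulfur gives a 1.3-fold higher number from compound 2 to compound 3 (0.10 log units; within the scatter), so with pyridin-3-yl held constant, the two groups cannot be told apart at this position. Among these compounds, the new compound also gives the first comparison of the pyridine groups that differs in one place: pyridin-3-yl in place of pyridin-4-yl gives a 1.9-fold higher number from compound 1 to compound 3 (0.29 log units; within the scatter), and this too cannot be told from the scatter. No measurement is available that could explain either result.

Methyl and chloro each add one heavy atom, so it remains open whether an amine, a carboxylic acid or a longer chain at this position would shift the growth-inhibition value beyond the scatter. As far as these compounds go, it also remains open whether a phenyl group in place of the pyridine ring would do so.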